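Replacing a group on the amine nitrogen of compound 2

The compounds below may be only part of what the source reports. "The series", "measured", "known", "first", "only" and "open" are said of these compounds alone.

Measured in a functional assay on HeLa cells (Homo sapiens) for inhibition, read by CCK-8 assay, with a stated time of 48 h; on this read-out lower numbers stand for stronger inhibition and higher numbers for weaker inhibition:
- Compound 1 `COc1ccc(NC(=O)NCCNS(=O)(=O)c2sccc2-c2ccc(C)cc2Oc2ccc(O)c(O)c2)cc1`: > 20000 nM (a limit)
- Compound 2 `Cc1ccc(-c2ccsc2S(=O)(=O)NCCNC(=S)Nc2ccc([N+](=O)[O-])cc2)c(Oc2ccc(O)c(O)c2)c1`: 6800 nM

Among the measured compounds shown here, compound 2 holds the only actual number in this small set, because compound 1 stands at a limit of this assay. The next compound to be tested is compound 3 `Cc1ccc(-c2ccsc2S(=O)(=O)NCCNC(=O)Nc2cc(Cl)cc(Cl)c2)c(Oc2ccc(O)c(O)c2)c1`. It differs from compound 2 on the amine nitrogen: a group of 11 heavy atoms (7 carbon, 1 nitrogen, 1 oxygen, 2 chlorine; one six-membered aromatic ring of carbon only) in place of a group of 12 heavy atoms (7 carbon, 2 nitrogen, 2 oxygen, 1 sulfur; one six-membered aromatic ring of carbon only), on an amine nitrogen. The new group is (3,5-dichlorophenyl)carbamoyl.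

For the measured compounds named here, one measured step bears on this, made at the same amine nitrogen: an at least 2.9-fold lower number from compound 1 to compound 2 (0.46 log units; beyond the scatter). Compound 3 has a carbonyl there, as compound 1 does, so a slightly higher number is expected, though not one clearly beyond the scatter. The expected change is a 1.6-fold higher number from compound 2 to compound 3 (0.21 log units; within the scatter). For compound 3 the estimated value is 11000 nM, with an expected range of 4500 nM to 20000 nM.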

Compound 3, half-maximal inhibitory concentration: 6500 nM
Beside the measured number, compound 3's estimate is 1.7-fold (0.23 log units) above it; the range from low to high includes it.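

In this assay, the exchange at the amine nitrogen gives a 1.0-fold lower number from compound 2 to compound 3 (0.02 log units; within the scatter), which shows that the sulfur-containing group of compound 2 is not needed for a measurable number at this position. With the carbonyl kept, 3,5-dichlorophenyl in place of 4-methoxyphenyl on the amide-type nitrogen gives an at least 3.0-fold lower number from compound 1 to compound 3 (0.48 log units; beyond the scatter), so a change in the aromatic group alone is enough to move the number. The size of that step has only a lower bound, set by a limit and not by a number: the limit of > 20000 nM in this assay, at which 1 of the 3 values shown sits.

Still open, as far as these compounds go, is how 4-nitrophenyl would read with the carbonyl, or 3,5-dichlorophenyl with the sulfur-containing linkage, which would separate the two parts changed together from compound 1 to compound 2. Also open, from the compounds shown here alone, is what an amine or a carboxylic acid on that aromatic ring, or a longer saturated chain, would do to the number.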